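Chain-linked quaternary ammonium analogues: compound 3 to compound 4

The source may hold more compounds than are shown below. What is called first, only, known or untested is meant among the compounds shown, and "the series" means these compounds.

Measured compounds:
- compound 1 `CN(C)c1ccc2c(=O)c(C(=O)Nc3cc(F)cc(F)c3)cn(-c3ccc(OCCCCCCC[N+]45CCN(CC4)CC5)cc3Cl)c2n1`: 40.1%
- compound 2 `CN(C)c1ccc2c(=O)c(C(=O)Nc3cc(F)cc(F)c3)cn(-c3ccc(OCCCCCCC[N+]4(C)CCCC4)cc3Cl)c2n1`: "not active" (no number reported), no number
- compound 3 `Cc1cc(OCCCCCCC[N+]2(C)CCCCC2)ccc1-n1cc(C(=O)Nc2cc(F)cc(F)c2)c(=O)c2ccc(N(C)C)nc21`: "not active" (no number reported), no number

In an assay on LX2 cells for inhibition of COL1A1 promoter (Homo sapiens), read by a luciferase reporter, with a stated time of 24 h, tested at 20 uM (on this read-out higher numbers stand for a stronger effect at the one concentration tested and lower numbers for a weaker effect), compound 1 gives 40.1%. Compound 2 carries no number in this assay and is recorded only as "not active" (no number reported). Compound 3 stands in the same position: in this assay compound 3 is recorded as "not active" (no number reported), without a figure, so no order can be set between compound 3 and compound 2, and the one numbered entry in the set, that of compound 1, is the only point above the not-active line.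

Compound 4 `CN(C)c1ccc2c(=O)c(C(=O)Nc3cc(F)cc(F)c3)cn(-c3ccc(OCCCCCCC[N+]4(C)CCCCC4)cc3Cl)c2n1` is the unmeasured member. It differs from compound 3 in one place, (chloro in place of methyl on an aromatic carbon), on an aromatic carbon of a six-membered aromatic ring of carbon only, ortho to a large group and meta to a large group. For the measured compounds named here, no step between measured compounds is recorded for this change, so its size and direction here are not known. Compound 1 and compound 2, which both carry the chloro, show one numbered result and one not-active entry, so the chloro alone does not decide the outcome.

Compound 4 is expected at 15%, within 0% to 40%.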

Compound 4, a percentage reported as inhibition, at one concentration (the size of the read-out at that concentration, not a potency): "not active" (no number reported)
Compound 4 has no reported number here, and the estimate cannot be compared.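

Compound 3 and compound 4 both stand without a number in this assay, so no step can be read for chloro in place of methyl. Nothing available bears on a cause for this result. The compounds shown leave open what size or direction this change would take in a pair with numbered values.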